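This account rests on a few compounds, and the source may have more. Where it says the series, first, only, none or still open, it means among the compounds named here.

Measured so far:
compound 1 `CCCCCCCc1cc(=O)c2cc([N+](=O)[O-])ccc2[nH]1` — in a physicochemical assay for solubility, read by HPLC, at pH 7.4 (on this read-out higher numbers stand for higher solubility and lower numbers for lower solubility), compound 1 gives only a limit, < 5000 nM.
compound 2 `CCCCCCCc1[nH]c2ccc([N+](=O)[O-])cc2c(=O)c1C(=O)O` — in this assay compound 2 gives 15000 nM.
compound 3 `CCCCCCCc1[nH]c2ccncc2c(=O)c1C(=O)O` — in this assay compound 3 gives 50000 nM.

Compound 3 stands highest of the two numbers, with compound 2 nearest at a gap beyond the scatter. The cores of compound 2 and compound 3 differ; that difference is not broken down here.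

One change is seen twice in the set. From compound 2 to compound 1 it is hydrogen in place of carboxy on an aromatic carbon and it gives an at least 3.0-fold lower number from compound 2 to compound 1 (0.47 log units; beyond the scatter). The size of that step is known only as a bound because compound 1 sits at the limit of < 5000 nM in this assay, at which 1 of the 3 values shown sits.

Compound 4 `CCCCCCCc1cc(=O)c2cnccc2[nH]1` has not yet been measured. It differs from compound 3 by hydrogen in place of carboxy on an aromatic carbon, the same change as from compound 2 to compound 1, at a place described in the same words.

For compound 4 in this assay the expected step is a 5.0-fold lower number from compound 3 to compound 4 (0.70 log units; beyond the scatter), resting on the step from compound 2 to compound 1, an at least 3.0-fold lower number from compound 2 to compound 1 (0.47 log units; beyond the scatter), and on the value of compound 3, 50000 nM. The estimate for compound 4 is 10000 nM, expected between 3000 nM and 30000 nM.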

Compound 4, solubility: 50000 nM
Compound 4: middle estimate off by 5.0-fold (0.70 log units), on the low side, and the stated range ends below it.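

In this assay, hydrogen in place of carboxy on an aromatic carbon gives no change at the digits printed from compound 3 to compound 4 (within the scatter), whereas the same change on the core of compound 2 gives an at least 3.0-fold lower number from compound 2 to compound 1 (0.47 log units; beyond the scatter), so the step read on one core did not carry over to the other. The step on the core of compound 2 is only a bound, and compound 1 stands at a limit: the limit of < 5000 nM in this assay, at which 1 of the 4 values shown sits. These two pairs show that the effect of losing carboxy in this series can depend on the core, but they give no reason for the difference and no rule for any third core.

Still open, as far as these compounds go, is how an amine or a methyl ester at this aromatic carbon would read in this assay on either core. Also open, from the compounds shown here alone, is whether a chain longer than heptyl would keep the step from compound 3 to compound 4 as flat as it stands here.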